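The compounds below may be only part of what the source reports. "The series", "measured", "known", "first", "only" and "open" are said of these compounds alone.

Working notes on the series. For the measured compounds named here, compound 2 `COc1ccccc1-n1nc(C2CC(C)(C)OC(C)(C)C2)cc1-c1ccc(C#N)cc1` stands level with compound 1 `COc1ccccc1-n1nc(C2CC(C)(C)OC(C)(C)C2)cc1-c1ccc(Cl)cc1` on the numbers so far: in an assay on HEK293 cells for inhibition of Voltage-dependent N-type calcium channel subunit alpha-1B (Homo sapiens), read by fluorescence and calcium flux, with a stated time of 5 min (a higher number here means a weaker inhibitor, a lower number a stronger inhibitor), compound 1 gives 1 nM, and in this assay compound 2 gives 1 nM, the step of no change at the digits printed from compound 1 to compound 2 (within the scatter) lying within the scatter for a cyano in place of chloro on an aromatic carbon.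

Compound 3 `CCOc1ccc(-c2cc(C3CC(C)(C)OC(C)(C)C3)nn2-c2ccccc2OC)cc1` continues the exchange at the same aromatic carbon: ethoxy in place of cyano on an aromatic carbon. Going by the values given here, the one measured step that bears on this position, no change at the digits printed from compound 1 to compound 2 (within the scatter), was flat, so the site has so far tolerated an exchange of substituent without a shift beyond the scatter. Ethoxy is a larger and differently built group than either chloro or cyano, and no measured compound carries it, so the step of a 2.0-fold higher number from compound 2 to compound 3 (0.30 log units; within the scatter) is expected to be small, at most a modest loss. Compound 3 is therefore estimated at 2 nM in this assay, with a range from 0.5 nM to 10 nM.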

Compound 3, half-maximal inhibitory concentration: 2 nM
For compound 3 middle estimate and measured number coincide at the digits printed; the measured number falls inside the stated range.
By their numbers in this assay, from the lowest: compounds 1, 2 and 3 (each within the scatter of the next).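

In this assay the aromatic carbon now carries a third group, and ethoxy, with oxygen as its attached atom, gives a 2.0-fold higher number from compound 2 to compound 3 (0.30 log units; within the scatter) and a 2.0-fold higher number from compound 1 to compound 3 (0.30 log units; within the scatter). For the compounds shown here, the flat reading therefore extends beyond the single exchange of chloro and cyano: across these three groups, which differ in their atoms and in the triple bond of the cyano, no step leaves the scatter, and the numbers show no preference among them. The data offer no measured basis for explaining this tolerance.

Going by these compounds, whether the same carbon also tolerates an amine, a carboxylic acid or a longer chain such as butoxy remains open. Also open, on these data alone, is whether the flat reading at this position would hold with a different substituent elsewhere on the shared core.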